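The compounds below may be only part of what the source reports. "The series", "measured", "known", "first", "only" and "open" are said of these compounds alone.

Measured compounds:
- compound 1, `COc1ccc(Cl)cc1NS(=O)(=O)c1ccc(OC)c(N2CCNCC2)c1`: 1.26 nM in an assay on isolated protein for binding affinity to 5-hydroxytryptamine receptor 6 (Homo sapiens); a lower number here means a stronger inhibitor, a higher number a weaker inhibitor
- compound 2, `COc1ccc(S(=O)(=O)Nc2c(F)cc(Br)cc2F)cc1N1CCNCC1`: 158 nM in this assay
- compound 3, `COc1ccc(S(=O)(=O)Nc2cc(Br)cc(Br)c2Br)cc1N1CCNCC1`: 2.51 nM in this assay

Compound 3 gives the second highest of the three numbers in this assay. Its nearest neighbour is compound 1, with a 2.0-fold higher number from compound 1 to compound 3 (0.30 log units; within the scatter), a gap within the scatter; its furthest is compound 2, with a 63-fold lower number from compound 2 to compound 3 (1.80 log units; beyond the scatter), a gap well beyond it.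

Compound 4, `COc1ccc(S(=O)(=O)Nc2cc(Br)cc(Cl)c2Cl)cc1N1CCNCC1`, has not been measured. It differs from compound 3 in one place: 5-bromo-2,3-dichlorophenyl in place of 2,3,5-tribromophenyl on a sulfonamide nitrogen. The aryl group on the sulfonamide nitrogen therefore keeps its substitution pattern but carries two chlorines where compound 3 carries two bromines.

For the measured compounds named here, no measured step exchanges bromine for chlorine on this aryl group. The steps that touch the same position are a 130-fold higher number from compound 1 to compound 2 (2.10 log units; beyond the scatter) and a 63-fold lower number from compound 2 to compound 3 (1.80 log units; beyond the scatter), both large, but each rewrites the whole aryl group, including the positions of the halogens. The step of a 2.0-fold higher number from compound 1 to compound 3 (0.30 log units; within the scatter) shows that a chloro-methoxy aryl and a tribromo aryl sit within the scatter of one another. A swap of halogen type at fixed positions is a smaller change than any of these. In this assay compound 4 is expected to stay close to compound 3, with a 1.6-fold higher number from compound 3 to compound 4 (0.20 log units; within the scatter) as the expected step. The estimate for compound 4 is 4 nM, with a range from 1.5 nM to 12 nM.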

Compound 4, inhibition constant: 3.98 nM
For compound 4 the middle estimate is 1.0-fold (0.00 log units) above the measured one, and the stated range covers the measured number.
By their numbers in this assay, from the lowest: compounds 1, 3 and 4 (each within the scatter of the next, the first and the last beyond it); then compound 2.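

In this assay, for the compounds shown here,  replacing two bromines with two chlorines while keeping the substitution pattern of the group on the sulfonamide nitrogen gives a 1.6-fold higher number from compound 3 to compound 4 (0.20 log units; within the scatter), the first reading of a change in halogen type alone. The 5-bromo-2,3-dichlorophenyl group also stays far from the 4-bromo-2,6-difluorophenyl group, with a 40-fold lower number from compound 2 to compound 4 (1.60 log units; beyond the scatter), and it is separated from the 5-chloro-2-methoxyphenyl group by a 3.2-fold higher number from compound 1 to compound 4 (0.50 log units; beyond the scatter), a modest step beyond the scatter, even though compound 3 lies within the scatter of compound 1 and of compound 4. No independent evidence bears on the reason for these steps.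

The compounds shown do not separate the kind of halogen from its placement in the large step involving the 4-bromo-2,6-difluorophenyl group, since no fluorine-bearing aryl group here shares the substitution pattern of compound 3 or compound 4. Also open, going by these compounds, is how an aryl group carrying a nitrile, an amine or a carboxylic acid in place of a halogen would read in this assay.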